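The compounds below may be only part of what the source reports. "The series", "measured", "known", "first", "only" and "open" are said of these compounds alone.

Compound 1 `C=C1C(=O)O[C@H]2CC3=C[C@H](C/C(C)=C/[C@@H](OC(=O)c4ccc(C(C)=O)cc4)[C@H]12)OC3=O` is the starting point of this comparison. In a functional assay on A549 cells (Homo sapiens) for cytotoxicity, read by MTT assay, with a stated time of 48 h (on this read-out lower numbers stand for stronger inhibition and higher numbers for weaker inhibition), compound 1 gives 2300 nM, the smallest number among the three compounds measured, although the other two lie within the usual scatter of it. Compound 2 `C=C1C(=O)O[C@H]2CC3=C[C@H](C/C(C)=C/[C@@H](OC(=O)C45CCC(C)(C(=O)O4)C5(C)C)[C@H]12)OC3=O` gives 3400 nM in this assay, and compound 3 `C=C1C(=O)O[C@H]2CC3=C[C@H](C/C(C)=C/[C@@H](OC(=O)C4CC4)[C@H]12)OC3=O` gives 3200 nM. The only place that varies across the set is the group on the carbonyl carbon of the ester, and none of the changes there has moved the read-out: the step of a 1.5-fold higher number from compound 1 to compound 2 (0.17 log units; within the scatter) and the step of a 1.4-fold higher number from compound 1 to compound 3 (0.14 log units; within the scatter) both stay within the scatter, as does the step of a 1.1-fold lower number from compound 2 to compound 3 (0.03 log units; within the scatter).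

Compound 4 `C=C1C(=O)O[C@H]2CC3=C[C@H](C/C(C)=C/[C@@H](OC(=O)CC(C)C)[C@H]12)OC3=O` extends the same series with a further exchange at that position: isobutyl in place of 4-acetylphenyl on a carbonyl carbon. Going by the values given here, the groups already placed on that carbonyl carbon differ widely in size and ring content without any effect beyond the scatter, so there is no measured step to suggest that isobutyl would behave differently. Compound 4 is therefore expected to show a step of a 1.3-fold higher number from compound 1 to compound 4 (0.12 log units; within the scatter), which amounts to no change beyond the scatter. The estimate for compound 4 in this assay is 3000 nM, with a range from 1500 nM to 6000 nM.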

Compound 4, half-maximal inhibitory concentration: 2500 nM
Beside the measured number, compound 4's estimate is 1.2-fold (0.08 log units) above it; the range from low to high includes it.
By their numbers in this assay, from the lowest: compounds 1, 4, 3 and 2 (each within the scatter of the next).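

Isobutyl is the only group at this place without a ring, and in this assay its exchange for 4-acetylphenyl gives a 1.1-fold higher number from compound 1 to compound 4 (0.04 log units; within the scatter). The comparisons with the other two ring-bearing groups read the same, with a 1.3-fold lower number from compound 3 to compound 4 (0.11 log units; within the scatter) for isobutyl against cyclopropyl and a 1.4-fold lower number from compound 2 to compound 4 (0.13 log units; within the scatter) for isobutyl against the group of 11 heavy atoms. Across these four compounds, a ring in this group is therefore not required for the read-out to stay at this level, and no evidence is available on why the position tolerates these exchanges.

From the compounds shown here alone, it remains open whether an amine, a carboxylic acid or a longer alkyl chain on this carbonyl carbon would also leave the read-out within the scatter of these four compounds. It is equally open whether the ester link itself matters, as the compounds shown do not include an amide or a free hydroxyl group at this place on the shared core.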